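Shifting One Fluorine on the Aryl Group of Compound 2

A few compounds are considered here, and "the series" means these few. Any claim that something is new, unique, unknown or untested is made for them only; others in the source may bear on it.

Measured so far:
compound 1, `Nc1scc(CN2CCN(c3ccc(Cl)cc3Cl)CC2)c1C(=O)c1ccc(Cl)cc1`: 2%
compound 2, `Nc1scc(CN2CCN(c3c(F)cccc3F)CC2)c1C(=O)c1ccc(Cl)cc1`: -12%

In a functional assay on CHO cells with adenosine receptor A1 (Homo sapiens) as the target, read by cAMP accumulation and immunoassay, with a stated time of 6 min, tested at 0.01 uM (on this read-out lower numbers stand for a stronger effect and higher numbers for a weaker effect at the one concentration tested), compound 1 gives 2% and compound 2 gives -12%. Compound 2 stands lowest of the two numbers, and the step of a number 14 percentage points lower from compound 1 to compound 2 (beyond the scatter) separates it from its nearest neighbour. Compound 3, `Nc1scc(CN2CCN(c3cccc(F)c3F)CC2)c1C(=O)c1ccc(Cl)cc1`, differs from compound 2 by 2,3-difluorophenyl in place of 2,6-difluorophenyl on an amine nitrogen in a ring. For the measured compounds named here, the only measured step, a number 14 percentage points lower from compound 1 to compound 2 (beyond the scatter), altered the same aryl group and was modest; with both fluorines kept, a smaller step is expected here. Compound 3 is therefore estimated at -4%, range -20% to 12%, a step of a number 8 percentage points higher from compound 2 to compound 3 (within the scatter) expected to lie within the scatter.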

Compound 3, a percentage reported as activity, at one concentration (the size of the read-out at that concentration, not a potency): -13%
Compound 3: the middle estimate sits 9 percentage points above what was measured; low and high end bracket the measured number.
By their numbers in this assay, from the lowest: compounds 3 and 2 (each within the scatter of the next); then compound 1.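

In this assay, moving one fluorine gives a number 1 percentage points lower from compound 2 to compound 3 (within the scatter), so on this amine nitrogen the 2,6-difluorophenyl and 2,3-difluorophenyl groups cannot be told apart. The step of a number 15 percentage points lower from compound 1 to compound 3 (beyond the scatter) places compound 3, like compound 2, beyond the scatter from compound 1, which carries the 2,4-dichlorophenyl group. Nothing available explains this result. Going by these compounds, it remains open whether an unsubstituted phenyl, a methoxyphenyl or a pyridyl group would give a similar number here. A reading at one concentration shows only the size of the effect of compound 2 and compound 3 at that concentration.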